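A few compounds are considered here, and "the series" means these few. Any claim that something is new, unique, unknown or untested is made for them only; others in the source may bear on it.

Measured compounds:
compound 1, `C=CCOc1ccc(Br)cc1C(=O)c1cccnc1`, 88000 nM in a functional assay on IMR-32 cells (Homo sapiens) for cytotoxicity, read by sulforhodamine B assay, with a stated time of 48 h; a lower number here means a stronger inhibitor, a higher number a weaker inhibitor
compound 2, `O=C(c1cccnc1)c1cc(F)ccc1O`, 6210 nM in this assay

Of the two compounds measured in this assay, compound 2 gives the lower number, and compound 1 sits a step above it that lies beyond the usual scatter. Among the compounds with values here, no pair of measured compounds differs in a single place, so no single structural step has a measured size here; what separates compound 1 from compound 2 is more than one change at once.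

Compound 3, `O=C(c1cccnc1)c1cc(Br)ccc1O`, has not yet been measured in this assay. It differs from compound 2 in one place: bromo in place of fluoro on an aromatic carbon.

Within the data shown here, with no measured step of this kind to lean on, the expected step from compound 2 to compound 3 is taken as a 1.2-fold lower number from compound 2 to compound 3 (0.09 log units; within the scatter), that is, nothing beyond the scatter in either direction. On that basis compound 3 is expected to give about 5000 nM in this assay, within a range from 1500 nM to 16000 nM.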

Compound 3, half-maximal inhibitory concentration: 23400 nM
Compound 3: the middle estimate sits 4.7-fold (0.67 log units) below what was measured, and the stated range ends below it.
By their numbers in this assay, from the lowest: compound 2; then compound 3; then compound 1.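

In this assay, the aromatic carbon para to the hydroxy group proves sensitive to which halogen it carries: bromo in place of fluoro gives a 3.8-fold higher number from compound 2 to compound 3 (0.58 log units; beyond the scatter) and moves the number beyond the scatter. With bromo held fixed, hydrogen in place of allyl on the oxygen gives a 3.8-fold lower number from compound 1 to compound 3 (0.58 log units; beyond the scatter), so the two changes that separate compound 1 from compound 2 now each have a measured size, and both steps favour compound 2's features over those of compound 1. Nothing available explains either step.

The compounds shown leave open how chloro, a methoxy group or an amine would fare at this position. They also leave open whether a methyl group on the oxygen would give a number nearer that of allyl or that of hydrogen, and whether the allyl step would hold with fluoro in place of bromo.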